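The source may hold more compounds than are shown below. What is called first, only, known or untested is meant among the compounds shown, and "the series" means these compounds.

Measured compounds:
Compound 1 `CNc1nc(-c2ccccc2)nc2c1nnn2Cc1ccccc1` gives 353 nM in an assay on Cerebral cortex for displacement of a labelled ligand from adenosine receptor A1 (Bos taurus); a lower number here means a stronger inhibitor, a higher number a weaker inhibitor.
Compound 2 `CCCNc1nc(-c2ccccc2)nc2c1nnn2Cc1ccccc1` gives 37 nM in this assay.

Going by the values given here, compound 2 stands at the lowest of the two numbers measured so far, its nearest neighbour being compound 1, separated from it by a 9.5-fold lower number from compound 1 to compound 2 (0.98 log units; beyond the scatter). The step to be followed leads from compound 2 to compound 3 `CCCCCCNc1nc(-c2ccccc2)nc2c1nnn2Cc1ccccc1`: propyl in place of hydrogen on a saturated chain carbon, three bonds along the chain from a nitrogen on an aromatic ring. Among the compounds with values here, only one measured step bears on this change, the chain extension within the same alkylamino position from compound 1 to compound 2, which gave a 9.5-fold lower number from compound 1 to compound 2 (0.98 log units; beyond the scatter). Within the data shown here, whether further lengthening keeps lowering the number or turns back cannot be read from two points; the single step argues against a large rise, but it does not establish a continued fall. The expected step from compound 2 to compound 3 is therefore a 1.2-fold higher number from compound 2 to compound 3 (0.09 log units; within the scatter), a change not clearly beyond the scatter. Compound 3 is estimated at 45 nM, with a range from 10 nM to 200 nM.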

Compound 3, inhibition constant: 13.2 nM
For compound 3 the middle estimate is 3.4-fold (0.53 log units) above the measured one, within the range that was stated.
By their numbers in this assay, from the lowest: compound 3; then compound 2; then compound 1.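

In this assay the fall in the number continues past propyl to hexyl, with a 2.8-fold lower number from compound 2 to compound 3 (0.45 log units; beyond the scatter), so lengthening the chain on the nitrogen on the aromatic ring has not yet turned back. This step is smaller than a 9.5-fold lower number from compound 1 to compound 2 (0.98 log units; beyond the scatter), while the whole extension gives a 27-fold lower number from compound 1 to compound 3 (1.43 log units; beyond the scatter); among these three compounds the number falls with each lengthening, and none goes against this. Nothing available accounts for this trend.

Open, as far as these compounds go, is whether a longer chain than hexyl lowers the number further, levels off or reverses the trend. Also open, from the compounds shown here alone, is how a branched chain, a cyclohexyl group or a chain ending in a hydroxyl group would compare with the hexyl chain at this nitrogen.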